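Working notes: phenyl in place of fluoro

A few compounds are considered here, and "the series" means these few. Any claim that something is new, unique, unknown or untested is made for them only; others in the source may bear on it.

Measured in a functional assay on P388 cells (Mus musculus) for antiproliferative activity, read by colorimetric assay and MTT assay; a lower number here means a stronger inhibitor, a higher number a weaker inhibitor
compound 1 `O=S(=O)(Nc1cccc2c(Cl)c[nH]c12)c1ccc(Cl)cc1` gives 4.3 ug/mL
compound 2 `Nc1ccc(S(=O)(=O)Nc2ccc(F)c3c(Cl)c[nH]c23)cc1` gives 0.51 ug/mL

Compound 2 holds the lower of the two numbers, and the gap up to compound 1 lies beyond the scatter. Compound 3 `Nc1ccc(S(=O)(=O)Nc2ccc(-c3ccccc3)c3c(Cl)c[nH]c23)cc1` differs from compound 2 by phenyl in place of fluoro on an aromatic carbon. Going by the values given here, no measured step at this place exists, so the expectation rests on the structural change alone. In this assay a moderate move to a higher number is expected, slightly beyond the scatter. a 2.9-fold higher number from compound 2 to compound 3 (0.47 log units; beyond the scatter) is the estimated step. Compound 3 is expected at 1.5 ug/mL within an estimated range from 0.4 ug/mL to 6 ug/mL on measurement.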

Compound 3, half-maximal inhibitory concentration: 19 ug/mL
Estimate against measurement, compound 3: 13-fold (1.10 log units) below; the measured number lies above the stated range.
By their numbers in this assay, from the lowest: compound 2; then compound 1; then compound 3.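

In this assay, going by these compounds alone, phenyl in place of fluoro on an aromatic carbon gives a 37-fold higher number from compound 2 to compound 3 (1.57 log units; beyond the scatter), the only single-place step so far. This position, para to a large group, is therefore sensitive to its substituent, and replacing fluoro with phenyl here is clearly unfavourable. No available evidence explains the size of this step.

From the compounds shown here alone, whether methyl, methoxy or an amine at this place would keep the number near that of compound 2 remains open. So does whether a phenyl bearing a carboxylic acid would recover any of the loss.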